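1H-indazol-6-yl for 1-benzofuran-5-yl: notes on compound 3

The compounds below may be only part of what the source reports. "The series", "measured", "known", "first", "only" and "open" are said of these compounds alone.

Compound 1 `CCN(Cc1ccccc1)C(=O)C1CCN(S(=O)(=O)c2ccc3occc3c2)CC1` and compound 2 `CCN(C(=O)C1CCN(S(=O)(=O)c2ccc3occc3c2)CC1)[C@H](C)c1ccccc1` share the core of compound 1. In a functional assay on CHO cells for positive allosteric modulation of muscarinic acetylcholine receptor M5 (Homo sapiens), read by calcium flux (on this read-out higher numbers stand for larger maximal responses and lower numbers for smaller maximal responses), compound 1 gives 80%, and in this assay compound 2 gives 80%. Among the measured compounds shown here, the single measured step, no change at the digits printed from compound 1 to compound 2 (within the scatter), consists of a methyl in place of hydrogen on a saturated chain carbon bound to an amide-type nitrogen and an aromatic carbon. Compound 2 thus stands level with compound 1, its nearest neighbour, at the digits shown.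

Compound 3 `CCN(C(=O)C1CCN(S(=O)(=O)c2ccc3cn[nH]c3c2)CC1)[C@H](C)c1ccccc1` differs from compound 2 by 1H-indazol-6-yl in place of 1-benzofuran-5-yl on a sulfonyl sulfur. For the measured compounds named here, no measured step touches the group on the sulfonyl sulfur; the only step available concerns the saturated chain carbon and was flat. The measured material therefore gives no direction for the change on the sulfonyl sulfur, and the value of compound 2 is the only anchor. Going by the values given here, with no bearing step, the expected step of a number 2 percentage points lower from compound 2 to compound 3 (within the scatter) is none beyond the scatter, but the range is set wide to reflect the untested replacement. Compound 3 is estimated at 78%, with a range from 50% to 100%.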

Compound 3, largest response reached (reported as percent of maximum), in percent of the reference or control that the assay uses: 87%
Compound 3: middle estimate off by 9 percentage points, on the low side; measured number inside the range.
By their numbers in this assay, from the lowest: compounds 1, 2 and 3 (each within the scatter of the next).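

In this assay, among the compounds shown here, the first measured change on the sulfonyl sulfur, 1H-indazol-6-yl in place of 1-benzofuran-5-yl, gives a number 7 percentage points higher from compound 2 to compound 3 (within the scatter), so this position accepts a different fused aromatic group while the maximal response stays within the scatter. The entering group brings a hydrogen-bond donor that the leaving group lacks and a five-membered ring with two hetero atoms in place of one, and neither difference takes the read-out beyond the scatter in this pair. Nothing measured here explains this outcome or separates the contribution of the donor from that of the ring atoms or the point of attachment.

Open, on these data alone, is whether the hydrogen on the indazole ring nitrogen matters at all, a question that a 1-methyl-1H-indazol-6-yl group on the sulfonyl sulfur would address, and whether the fused ring itself is needed, which a plain phenyl or a pyridyl group there would test. Also open, as far as these compounds go, is how far the response holds when the ethyl group on the amide-type nitrogen gives way to a cyclopropyl group or a longer chain.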